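Triaryl triazole series: aryl group on ring nitrogen varied

The source may hold more compounds than are shown below. What is called first, only, known or untested is meant among the compounds shown, and "the series" means these compounds.

Measured so far:
compound 1 `Oc1cc(C(F)(F)F)ccc1-c1nc(-c2ccccc2O)n(-c2ccccc2C(F)(F)F)n1`: 71%
compound 2 `Cc1ccc(-n2nc(-c3ccc(C(F)(F)F)cc3O)nc2-c2ccccc2O)c(C)c1`: 73.7%

Within the data shown here, both compounds have been tested in a functional assay on PC-12 cells (Rattus norvegicus) for cytotoxicity, read by MTT assay, with stated times of 2 h and 24 h, tested at 1 uM; a lower number here means a weaker effect, a higher number a stronger effect of the compound at the concentration tested. Compound 1 gives 71% and compound 2 gives 73.7%, the latter being the higher of the two numbers on record, though the step of a number 2.7 percentage points higher from compound 1 to compound 2 (within the scatter) lies within the scatter, so the two are not distinguished.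

Compound 3 `Cc1cc(C)cc(-n2nc(-c3ccc(C(F)(F)F)cc3O)nc2-c2ccccc2O)c1` is not yet measured. It differs from compound 2 as follows: 3,5-dimethylphenyl in place of 2,4-dimethylphenyl on an aromatic nitrogen. Among the measured compounds shown here, the one measured step that bears on this change is a number 2.7 percentage points higher from compound 1 to compound 2 (within the scatter), which also swapped the aryl group on an aromatic nitrogen of the shared core and produced no movement beyond the scatter. For the measured compounds named here, on that basis no step beyond the scatter is expected for the rearrangement of the two methyl groups within the aryl group on an aromatic nitrogen; the data hold no example of such a rearrangement, so the expectation rests on the single step available.

Compound 3 is therefore expected to give about 73% in this assay, with a range of 60% to 85%. The expected step is a number 0.7 percentage points lower from compound 2 to compound 3 (within the scatter), within the scatter.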

Compound 3, a percentage reported as activity, at one concentration (the size of the read-out at that concentration, not a potency): 76.9%
Compound 3: middle estimate off by 3.9 percentage points, on the low side; measured number inside the range.
By their numbers in this assay, from the lowest: compounds 1, 2 and 3 (each within the scatter of the next).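

Moving the two methyl groups from the 2,4-dimethylphenyl to the 3,5-dimethylphenyl arrangement on the aromatic nitrogen gives a number 3.2 percentage points higher from compound 2 to compound 3 (within the scatter) in this assay, so this pair, with the same atoms joined differently, adds a rearrangement within the aryl group to the earlier swap of one aryl group for another. Replacing the 2-(trifluoromethyl)phenyl group with 3,5-dimethylphenyl at the same place gives a number 5.9 percentage points higher from compound 1 to compound 3 (within the scatter), which means that no step among these three aryl groups leaves the scatter and the read-out at this one concentration does not separate them. Nothing available on these compounds offers an explanation for the read-out staying this close across the three.

On these data alone, all three compounds carry a phenyl ring with methyl or trifluoromethyl groups on this nitrogen, so it remains open how the read-out would respond to a phenyl ring bearing an amine or a carboxylic acid, or to a longer alkyl chain in place of the aryl group. The 2-hydroxyphenyl group and the shared core are also constant across the series, which leaves their contribution open, along with how the read-out would behave at other concentrations.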